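The source may hold more compounds than are shown below. What is called first, only, known or untested is meant among the compounds shown, and "the series" means these compounds.

Compound 1 `Oc1ccc(-c2cc(-c3ccccc3)cc(-c3cccnc3)n2)cc1`: 13600 nM
Compound 2 `Oc1cccc(-c2cc(-c3ccccc3)nc(-c3ccccc3)c2)c1`: 15100 nM

In a functional assay on HeLa cells (Homo sapiens) for cytotoxicity, read by ELISA, with a stated time of 2 days (a higher number here means a weaker inhibitor, a lower number a stronger inhibitor), compound 2 stands at the upper end of the two numbers, a position that means little, since compound 1 at 13600 nM lies within the scatter of it. Compound 3 `Oc1cccc(-c2cc(-c3ccccc3)nc(-c3ccsc3)c2)c1` is not yet measured; its difference from compound 2 is thiophen-3-yl in place of phenyl on an aromatic carbon. Among the measured compounds shown here, no step between measured compounds exists to guide the expectation, and a thiophen-3-yl group entering where a phenyl group leaves is a small change, so the expected step in this assay, a 1.1-fold lower number from compound 2 to compound 3 (0.03 log units; within the scatter), is none beyond the scatter. Compound 3 is expected to give 14000 nM, within 5000 nM to 40000 nM.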

Compound 3, half-maximal inhibitory concentration: 14900 nM
The estimate for compound 3 lay 1.1-fold (0.03 log units) below the measured number; the range from low to high includes it.
By their numbers in this assay, from the lowest: compounds 1, 3 and 2 (each within the scatter of the next).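

Among the compounds shown here, this is the first step between two measured compounds that differ in one place. In this assay, putting thiophen-3-yl in place of phenyl on the aromatic carbon next to the ring nitrogen gives a 1.0-fold lower number from compound 2 to compound 3 (0.01 log units; within the scatter), so this swap of one aromatic ring for another does not separate the two compounds. No other measurement here offers an explanation for this result. The compounds shown leave open whether an amine or a short alkyl chain at this place would move the number beyond the scatter.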